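Trimming the Phenyl: From Compound 1 to Compound 3

The source may hold more compounds than are shown below. What is called first, only, known or untested is meant among the compounds shown, and "the series" means these compounds.

Compound 1, `C/N=C(/NC#N)NCCCCCn1nc(-c2ccccc2)ccc1=O`: 47.6%
Compound 2, `CCC/N=C(/NC#N)NCCCCCn1nc(-c2ccccc2)ccc1=O`: 27.5%

In a functional assay on the whole organism with Rattus norvegicus as the target, at a dose of 100 mg/kg (on this read-out lower numbers stand for less inhibition and higher numbers for more inhibition at the one dose given (going by the name of the read-out)), compound 1 gives 47.6%, the higher of the two numbers. For the measured compounds named here, compound 2 gives 27.5%, so the only measured step, a number 20.1 percentage points lower from compound 1 to compound 2 (beyond the scatter), lies beyond the scatter. Compound 3, `C/N=C(/NC#N)NCCCCCn1nc(C)ccc1=O`, differs from compound 1 by methyl in place of phenyl on an aromatic carbon. Going by the values given here, that measured step concerns the saturated chain end, not the aromatic carbon, so no measured step bears on this change and the expectation rests on the size of the one known step alone. Compound 3 is expected to give 30%, estimated between 5% and 60%, an expected step of a number 17.6 percentage points lower from compound 1 to compound 3 (beyond the scatter).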

Compound 3, a percentage reported as inhibition, in the whole organism at one dose (the size of the read-out at that dose, not a potency): 14.9%
Estimate against measurement, compound 3: 15.1 percentage points above; low and high end bracket the measured number.
By their numbers in this assay, from the lowest: compound 3; then compound 2; then compound 1.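

In this assay, methyl in place of phenyl on this aromatic carbon gives a number 32.7 percentage points lower from compound 1 to compound 3 (beyond the scatter) and is a large step. The earlier compounds shown here showed change only at the saturated chain end, whereas this result shows that the read-out also responds to the group on the aromatic carbon. Nothing at hand explains this step.

The compounds shown leave open whether a cyclohexyl ring or a pyridyl ring on this carbon would keep the number of compound 1 . They also leave open whether a methoxyphenyl group would raise it.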